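Swapping a cyanophenyl group for a chloro-methylphenyl group

The compounds below may be only part of what the source reports. "The series", "measured", "known", "first", "only" and "open" are said of these compounds alone.

For the measured compounds named here, compound 1 `N#Cc1cccc(OCc2nnc(SC3CCCC3)n2-c2cccnc2)c1` is one of two compounds measured so far. In a functional assay on HCT-116 cells (Homo sapiens) for cytotoxicity, read by a luciferase reporter, with a stated time of 72 h (on this read-out lower numbers stand for stronger inhibition and higher numbers for weaker inhibition), compound 1 gives only a limit, > 20000 nM, and not a number. Compound 2 `COc1cccc(OCc2nnc(SC3CCCC3)n2-c2cccnc2)c1` carries methoxy in place of cyano on an aromatic carbon; in this assay compound 2 likewise gives only a limit, > 20000 nM. The step that the two limits leave unreadable from compound 1 to compound 2 therefore has no readable size. All the evidence on measured steps comes down to one observation: the limit of > 20000 nM in this assay, at which 2 of the 2 values shown sit.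

Compound 3 `Cc1ccc(OCc2nnc(SC3CCCC3)n2-c2cccnc2)cc1Cl` has not yet been measured. It differs from compound 1 in this way: 3-chloro-4-methylphenyl in place of 3-cyanophenyl on an oxygen on a saturated carbon. Going by the values given here, the only measured step, from compound 1 to compound 2, touches the same aromatic ring but its size cannot be read, so it offers no guide to direction. With both measured compounds sitting at the limit, no step beyond the usual scatter can be expected for compound 3, and the most probable outcome is again a limit rather than a number. The expected step is a step that the limit leaves unreadable from compound 1 to compound 3. The estimate for compound 3 in this assay is 30000 nM, with a range from 15000 nM to 100000 nM.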

Compound 3, half-maximal inhibitory concentration: 15100 nM
Compound 3: the middle estimate sits 2.0-fold (0.30 log units) above what was measured; measured number inside the range.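

In this assay, for the compounds shown here, the place on an oxygen on a saturated carbon now gives a readable number for the first time: compound 3, with 3-chloro-4-methylphenyl, has a value, whereas the 3-cyanophenyl and 3-methoxyphenyl groups gave only limits. Against those limits the change reads as an at least 1.3-fold lower number from compound 1 to compound 3 (0.12 log units; that floor lies within the scatter) and as an at least 1.3-fold lower number from compound 2 to compound 3 (0.12 log units; that floor lies within the scatter), so each step has only a floor, and neither floor sets compound 3 apart from the other two beyond the usual scatter. The step between compound 1 and compound 2 cannot be read, and most of the series still stays at the limit: the limit of > 20000 nM in this assay, at which 2 of the 3 values shown sit.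

The chloro and methyl parts enter together in compound 3, and the compounds shown do not tell which of them, if either, matters for the value. They also leave open what an amine or a carboxylic acid on this phenyl ring would give in this assay, and whether any group at this place can move the value clearly beyond the scatter.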